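Swapping chloro for fluoro: how far will the number move?

A few compounds are considered here, and "the series" means these few. Any claim that something is new, unique, unknown or untested is made for them only; others in the source may bear on it.

Two close relatives have been measured in a functional assay on T98G cells (Homo sapiens) for cytotoxicity, read by MTT assay, with a stated time of 48 h; a lower number here means a stronger inhibitor, a higher number a weaker inhibitor. Compound 1 `CC(=NNC(=S)Nc1ccc(I)cc1)c1ccccn1` gives 64 nM, and compound 2 `CC(=NNC(=S)Nc1ccc(Cl)cc1)c1ccccn1` gives 5.9 nM, the lower of the two numbers. Only the halogen separates them, and chloro in place of iodo brought an 11-fold lower number from compound 1 to compound 2 (1.04 log units; beyond the scatter), a large step beyond the scatter. Compound 3 `CC(=NNC(=S)Nc1ccc(F)cc1)c1ccccn1` makes one further swap, fluoro in place of chloro on an aromatic carbon. That earlier step is the only measured one that bears on this change, and it involves a different pair of halogens, so it fixes neither the size nor the direction of the next step. With no firm reason for a large move, compound 2 at 5.9 nM serves as the anchor in this assay. The expected change is small, a 1.4-fold higher number from compound 2 to compound 3 (0.13 log units; within the scatter), with no clear step beyond the scatter. For compound 3 the estimated value is 8 nM, with an expected range of 2 nM to 35 nM.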

Compound 3, half-maximal inhibitory concentration: 17 nM
Estimate against measurement, compound 3: 2.1-fold (0.33 log units) below, within the range that was stated.
By their numbers in this assay, from the lowest: compound 2; then compound 3; then compound 1.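

In this assay, three halogens have now been compared on this aromatic carbon, para to a large group, and the swap to fluoro is not neutral: the result is a 2.9-fold higher number from compound 2 to compound 3 (0.46 log units; beyond the scatter). Fluoro still gives a lower number than iodo, with a 3.8-fold lower number from compound 1 to compound 3 (0.58 log units; beyond the scatter), so the number does not climb steadily from fluoro through chloro to iodo, and chloro, the middle halogen of the three, gives the lowest number. No measurement available here explains why these halogens differ.

As far as these compounds go, whether a non-halogen group at this place, such as a methoxy group, an amine or a carboxylic acid, could match chloro remains open. So does whether the same order of the three halogens would hold on another carbon of this ring.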